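Swapping One Halogenated Ring for Another on an Agonist

The source may report more compounds than this note shows. Statements on the series, on what has been measured and on what is new or still open speak of the compounds shown alone.

For the measured compounds named here, compound 3 `N=C(NCCCc1c[nH]cn1)NCCC(c1ccc(Cl)cc1)c1ccccn1` gives 7.84 in a functional assay on cardiac atrium for agonist activity at histamine H2 receptor (Cavia porcellus) (a lower number here means a less potent compound, a higher number a more potent compound, by a factor of ten per unit of this negative logarithm), the highest of the three numbers measured so far. Compound 2 `COc1ccc(C(CC/N=C(\N)NCCCc2c[nH]cn2)c2ccccn2)cc1` gives 7.44 and compound 1 `N=C(NCCCc1c[nH]cn1)NCCCC(c1ccccc1)c1ccccn1` gives 6.61; compound 3 stands beyond the usual scatter above both. Compound 4 `N=C(NCCCc1c[nH]cn1)NCCC(c1cccc(F)c1)c1ccccn1` is compound 3 with one change: 3-fluorophenyl in place of 4-chlorophenyl on a saturated chain carbon bound to an aromatic carbon and a saturated chain carbon. Going by the values given here, no measured pair shows what exchanging one such ring for another does, so the size of this step cannot be read from the data. Both rings carry a halogen, and a small loss, or no change beyond the scatter, is expected. The expected step from compound 3 to compound 4 is a number 0.34 log units lower from compound 3 to compound 4 (beyond the scatter). Compound 4 is estimated at 7.5 in this assay, with a range from 7 to 8.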

Compound 4, negative logarithm of the half-maximal effective concentration: 7.88
Compound 4: middle estimate off by 0.38 log units, on the low side; low and high end bracket the measured number.
By their numbers in this assay, from the lowest: compound 1; then compound 2; then compounds 3 and 4 (each within the scatter of the next).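

In this assay, exchanging the ring at this place gives a number 0.04 log units higher from compound 3 to compound 4 (within the scatter) and so leaves the number unmoved. For the compounds shown here, this is the first reading of a ring exchange on this saturated chain carbon, and it shows that 3-fluorophenyl can stand in for 4-chlorophenyl here, though the two differ in both the halogen and where it sits. No measurement shown here offers an explanation for this. Both features change at once. Their separate contributions cannot be read. A 3-chlorophenyl or 4-fluorophenyl ring at this place would separate them.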